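Methoxy to isopropyl on the pendant aryl ring: notes

The source may hold more compounds than are shown below. What is called first, only, known or untested is meant among the compounds shown, and "the series" means these compounds.

Compound 1 `COc1ccccc1-c1nc2ccccc2n1CCCN1CCC(c2cccc(NC(C)=O)c2)CC1`; in an assay for displacement of a labelled ligand from melanin-concentrating hormone receptor 1 (Homo sapiens), read by fluorescence (on this read-out higher numbers stand for weaker inhibition and lower numbers for stronger inhibition), compound 1 gives 747 nM.
Compound 2 `COc1ccc(-c2nc3ccccc3n2CCCN2CCC(c3cccc(NC(C)=O)c3)CC2)cc1`; in this assay compound 2 gives 9 nM.

Compound 2 holds the lower of the two numbers. Going by the values given here, the only measured step, an 83-fold lower number from compound 1 to compound 2 (1.92 log units; beyond the scatter), exchanges 2-methoxyphenyl for 4-methoxyphenyl, a change of where the methoxy sits rather than of the group itself.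

Compound 3 `CC(=O)Nc1cccc(C2CCN(CCCn3c(-c4ccc(C(C)C)cc4)nc4ccccc43)CC2)c1` differs from compound 2 by isopropyl in place of methoxy on an aromatic carbon. Among the compounds with values here, no measured step exchanges the methoxy for another group, so the step from compound 2 to compound 3 has no direct precedent; an 83-fold lower number from compound 1 to compound 2 (1.92 log units; beyond the scatter) shows only that the position carrying the group matters. Keeping the group at that same position, a small loss in this assay is expected, near the scatter, as a 2.2-fold higher number from compound 2 to compound 3 (0.35 log units; beyond the scatter). Compound 3 is estimated at 20 nM, within 5 nM to 80 nM.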

Compound 3, half-maximal inhibitory concentration: 60 nM
The estimate for compound 3 lay 3.0-fold (0.48 log units) below the measured number; the range from low to high includes it.
By their numbers in this assay, from the lowest: compound 2; then compound 3; then compound 1.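

With the group kept at the same place, para to a large group, the exchange of 4-methoxyphenyl for 4-isopropylphenyl carries a cost in this assay (a 6.7-fold higher number from compound 2 to compound 3 (0.82 log units; beyond the scatter)), so the identity of the group matters here as well as its position, which the earlier pair could not show. A group with no oxygen still retains much of the gain over the 2-methoxyphenyl of compound 1 (a 12-fold lower number from compound 1 to compound 3 (1.10 log units; beyond the scatter)), so oxygen at this place is not required for a number well below that of compound 1. Nothing at hand bears on the origin of either difference.

Going by these compounds alone, only two groups are compared at this para place, so the roles of oxygen and of group size remain unseparated. From the compounds shown here alone, an amine, a carboxylic acid or a longer alkyl chain there would test this, and the effect of isopropyl at the place the methoxy occupies in compound 1 also remains open.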